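The source may hold more compounds than are shown below. What is called first, only, known or untested is meant among the compounds shown, and "the series" means these compounds.

Series notes on solubility. Compound 1 `COc1ccc(-c2cc(-c3cccc(S(C)(=O)=O)c3)cnc2N)cn1`, compound 2 `COc1ccc(-c2cc(-c3ccc(S(=O)(=O)N(C)C)cc3)cnc2N)cn1` and compound 3 `COc1ccc(-c2cnc(N)c(-c3ccc(OC)nc3)c2)cn1` share a common core and differ in one substituent. In a physicochemical assay for solubility, read by nephelometry, measured as kinetic solubility, at pH 2 (on this read-out higher numbers stand for higher solubility and lower numbers for lower solubility), compound 1 gives > 100 ug/mL, which is a limit of the assay, not a number. In this assay compound 2 likewise gives > 100 ug/mL, again only a limit. Compound 3 in this assay also returns a limit, > 100 ug/mL. Compound 2 thus sits at the limit of > 100 ug/mL in this assay, at which 3 of the 3 values shown sit, with no numerical value to rank it. Compound 4 `COc1ccc(-c2cc(-c3ccc(C(=O)O)cc3)cnc2N)cn1` follows from compound 2 by the change (carboxy in place of dimethylsulfamoyl on an aromatic carbon). Within the data shown here, no step between measured compounds is available, so the effect of this exchange cannot be read from the series. A moderate fall beyond the scatter is expected, an at least 1.6-fold lower number from compound 2 to compound 4 (0.22 log units; that floor lies within the scatter). For compound 4 the estimate in this assay is 60 ug/mL, ranging from 15 ug/mL to 150 ug/mL.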

Compound 4, solubility: 12.5 ug/mL
The estimate for compound 4 lay 4.8-fold (0.68 log units) above the measured number; the whole stated range lies above it.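

In this assay, among these compounds, compound 4 is the first compound of the series to give a number rather than a limit, so the exchange on this aromatic carbon can now be seen to matter: an at least 8.0-fold lower number from compound 2 to compound 4 (0.90 log units; beyond the scatter). That size is only a floor, since compound 2 carries a limit and not a number: the limit of > 100 ug/mL in this assay, at which 3 of the 4 values shown sit. Dimethylsulfamoyl and carboxy at this place therefore do not read alike.

As far as these compounds go, the full size of the step stays open. So does whether a primary carboxamide or a methyl ester on this carbon would stay at the limit or fall to the level of compound 4.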